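From Methyl to Methoxy on Compound 2

This account rests on a few compounds, and the source may have more. Where it says the series, first, only, none or still open, it means among the compounds named here.

Two related compounds have numbers in a functional assay on HepG2 cells (Homo sapiens) for inhibition, read by MTT assay, with a stated time of 48 h; a lower number here means a stronger inhibitor, a higher number a weaker inhibitor. Compound 1 `COc1cc(/C=C2\SC(=O)N(CCNC(=O)Nc3c(C)n(C)n(-c4ccccc4)c3=O)C2=O)cc(OC)c1OC` gives 10800 nM, while compound 2 `Cc1ccc(/C=C2\SC(=O)N(CC(=O)Nc3c(C)n(C)n(-c4ccccc4)c3=O)C2=O)cc1` gives 57600 nM. That is the higher of the two numbers, so compound 2 is the weaker inhibitor, by a gap beyond the usual scatter. The two differ in more than one place, so this gap cannot be tied to any single change.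

Compound 3 `COc1ccc(/C=C2\SC(=O)N(CC(=O)Nc3c(C)n(C)n(-c4ccccc4)c3=O)C2=O)cc1` departs from compound 2 in one place only: methoxy in place of methyl on an aromatic carbon. This is methoxy in place of methyl on an aromatic carbon, a change from 4-methylphenyl to 4-methoxyphenyl. Going by the values given here, no measured pair shows this change alone, so the forecast is loose. In this assay a small move towards a lower number is expected, a 1.3-fold lower number from compound 2 to compound 3 (0.11 log units; within the scatter), and it may stay within the scatter. For compound 3 the estimated value is 45000 nM, with an expected range from 18000 nM to 100000 nM.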

Compound 3, half-maximal inhibitory concentration: 68500 nM
Compound 3: middle estimate off by 1.5-fold (0.18 log units), on the low side; measured number inside the range.
By their numbers in this assay, from the lowest: compound 1; then compounds 2 and 3 (each within the scatter of the next).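

In this assay, replacing methyl with methoxy on the aromatic carbon para to a large group gives a step (a 1.2-fold higher number from compound 2 to compound 3 (0.08 log units; within the scatter)) that lies within the scatter, so the two compounds cannot be told apart at this position. Unlike the gap between compound 1 and compound 2, this result can be tied to a single change, and adding one oxygen here produces no readable difference in the number. Nothing measured here offers an explanation for this result.

From the compounds shown here alone, it remains open whether an amine, a carboxylic acid or a longer chain at this same position would move the number beyond the scatter. Also open, going by these compounds, is which of the several differences setting compound 1 apart from these two goes with its number.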